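Swapping Imidazole for Methylthiazole on a Shared Core

The compounds below may be only part of what the source reports. "The series", "measured", "known", "first", "only" and "open" are said of these compounds alone.

Three measured compounds share one core and differ only in the aromatic group attached to one ring carbon. Compound 1 `c1cnc(-c2ccccc2OCC2=NCCN2)nc1` carries pyrimidin-2-yl, and in a functional assay for activation of Alpha-1A adrenergic receptor (Homo sapiens), read by calcium flux (a lower number here means that less compound is needed, a higher number that more compound is needed for the effect), compound 1 gives 1260 nM. Compound 2 `c1c[nH]c(-c2ccccc2OCC2=NCCN2)c1` carries 1H-pyrrol-2-yl, and in this assay compound 2 gives 1.26 nM. Compound 3 `c1ccc(-c2ncc[nH]2)c(OCC2=NCCN2)c1` carries 1H-imidazol-2-yl; in this assay compound 3 gives 100 nM, the second highest of the three numbers, sitting between the other two. All steps among these three are large: a 1000-fold lower number from compound 1 to compound 2 (3.00 log units; beyond the scatter), a 13-fold lower number from compound 1 to compound 3 (1.10 log units; beyond the scatter), and a 79-fold higher number from compound 2 to compound 3 (1.90 log units; beyond the scatter). Compound 4 `Cc1csc(-c2ccccc2OCC2=NCCN2)n1` is not yet measured; it differs from compound 3 in that (4-methyl-1,3-thiazol-2-yl in place of 1H-imidazol-2-yl on an aromatic carbon). The three steps show that exchanging this five-membered group can shift the number strongly either way, yet none of them involves a sulfur-containing ring, so the direction is uncertain. For compound 4 the number in this assay is expected to be around 200 nM, with a range from 20 nM to 2000 nM. This estimate corresponds to an expected step of a 2.0-fold higher number from compound 3 to compound 4 (0.30 log units; within the scatter), one that may stay within the scatter.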

Compound 4, half-maximal effective concentration: 25.1 nM
Beside the measured number, compound 4's estimate is 8.0-fold (0.90 log units) above it; the range from low to high includes it.
By their numbers in this assay, from the lowest: compound 2; then compound 4; then compound 3; then compound 1.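

In this assay, the first sulfur-containing ring at this position brings a 4.0-fold lower number from compound 3 to compound 4 (0.60 log units; beyond the scatter), even though 4-methyl-1,3-thiazol-2-yl has no hydrogen-bond donor and 1H-imidazol-2-yl has one, so among these two groups the one with the donor does not give the lower number. The new group still falls short of 1H-pyrrol-2-yl, with a 20-fold higher number from compound 2 to compound 4 (1.30 log units; beyond the scatter), yet it clearly improves on pyrimidin-2-yl, with a 50-fold lower number from compound 1 to compound 4 (1.70 log units; beyond the scatter), and so takes second place among the four groups. Nothing available here explains why these groups differ.

This step changes the ring and adds a methyl group together, so the compounds shown cannot tell how much each part contributes. Open too, as far as these compounds go, is how the number would respond to a plain 1,3-thiazol-2-yl, or to an ethyl group or an amine in place of that methyl.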